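The source may hold more compounds than are shown below. What is called first, only, known or untested is meant among the compounds shown, and "the series" means these compounds.

Compound 2 `OC[C@H]1OC(n2cnc3c(-c4ccc(Cl)cc4)ncnc32)[C@H](O)[C@@H]1O` and compound 1 `COc1ccc(-c2ncnc3c2ncn3[C@@H]2O[C@H](COC(C)=O)[C@@H](OC(C)=O)[C@H]2OC(C)=O)cc1` were both tested in a functional assay on CCRF-CEM cells (Homo sapiens) for inhibition; on this read-out lower numbers stand for stronger inhibition and higher numbers for weaker inhibition. Compound 2 gives 900 nM, the lower of the two numbers, while compound 1 gives 4300 nM. The two differ in several places, so their values are simply set side by side here.

Compound 3 `CCOc1ccc(-c2ncnc3c2ncn3C2O[C@H](CO)[C@@H](O)[C@H]2O)cc1` is built from compound 2 by one change: ethoxy in place of chloro on an aromatic carbon. Within the data shown here, no single-change step between measured compounds is available to gauge this exchange. A modest weakening is expected, a 2.0-fold higher number from compound 2 to compound 3 (0.30 log units; within the scatter), with the step from compound 2 to compound 3 likely falling close to the scatter. Compound 3 is estimated at 1800 nM, within a range of 600 nM to 5000 nM.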

Compound 3, half-maximal inhibitory concentration: 600 nM
For compound 3 the middle estimate is 3.0-fold (0.48 log units) above the measured one; measured number inside the range.
By their numbers in this assay, from the lowest: compounds 3 and 2 (each within the scatter of the next); then compound 1.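

Replacing 4-chlorophenyl with 4-ethoxyphenyl in this assay gives a 1.5-fold lower number from compound 2 to compound 3 (0.18 log units; within the scatter) and so leaves the reading essentially unchanged. This aromatic carbon, para to a large group, therefore carries ethoxy, with three heavy atoms and one hydrogen-bond acceptor, as well as chloro, with one heavy atom and no acceptor. Nothing available here explains this result.

From the compounds shown here alone, whether this tolerance extends to an amine, a carboxylic acid or a longer chain such as butoxy at the same place remains open. A single exchange cannot show how far it reaches.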